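Removing One Methyl Group: What Compound 3 Might Show

The compounds below may be only part of what the source reports. "The series", "measured", "known", "first", "only" and "open" are said of these compounds alone.

Of the compounds shown here, two have been measured in a functional assay, tested at 10 uM; a lower number here means a weaker effect, a higher number a stronger effect of the compound at the concentration tested. Compound 1 `O=C(Cn1c(=O)c(-c2ccc(O)c(O)c2)nc2ccccc21)NS(=O)(=O)C(F)(F)F` carries a 3,4-dihydroxyphenyl group on the shared core, and compound 1 gives 81.4%. Among the measured compounds shown here, compound 2 `COc1cc(/C=C/c2nc3ccccc3n(CC(=O)NS(=O)(=O)C(F)(F)F)c2=O)ccc1O` carries 2-(4-hydroxy-3-methoxyphenyl)ethenyl in place of that group, and in this assay compound 2 gives 52.2%, the lower of the two numbers; the single measured step, a number 29.2 percentage points lower from compound 1 to compound 2 (beyond the scatter), tells how far it falls short.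

Compound 3 `O=C(Cn1c(=O)c(/C=C/c2ccc(O)c(O)c2)nc2ccccc21)NS(=O)(=O)C(F)(F)F` differs from compound 2 by hydrogen in place of methyl on an oxygen on an aromatic ring, so its side group becomes 2-(3,4-dihydroxyphenyl)ethenyl. For the measured compounds named here, no measured step isolates this change: the step from compound 1 to compound 2 bundled it together with the exchange of 3,4-dihydroxyphenyl for the longer ethenyl-linked group, so it offers only a loose guide. If part of that drop belonged to the methyl, compound 3 is expected to recover some activity, as a number 15.8 percentage points higher from compound 2 to compound 3 (beyond the scatter). Compound 3 is therefore estimated at 68%, within a range from 48% to 88%.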

Compound 3, a percentage reported as activity, at one concentration (the size of the read-out at that concentration, not a potency) in the functional assay: 82.1%
Compound 3: the middle estimate sits 14.1 percentage points below what was measured; low and high end bracket the measured number.
By their numbers in the functional assay, from the lowest: compound 2; then compounds 1 and 3 (each within the scatter of the next).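

In the functional assay, the methyl on the oxygen matters on its own: a number 29.9 percentage points higher from compound 2 to compound 3 (beyond the scatter). With the 3,4-dihydroxyphenyl group kept, adding the ethenyl link leaves no visible mark, as the step is a number 0.7 percentage points higher from compound 1 to compound 3 (within the scatter), so the earlier fall seen with compound 2 tracks the methyl rather than the link. The same exchange of methyl for hydrogen also shifts lipophilicity in a physicochemical assay for lipophilicity, read by HPLC, using the shake flask method, measured as octanol-water partition, with a stated time of 24 h, at pH 7.4; on this read-out higher numbers stand for higher lipophilicity and lower numbers for lower lipophilicity: the measured distribution coefficient of compound 2, 1.05, and of compound 3, -1.08, a number 2.13 log units lower (beyond the scatter) In the physicochemical assay compound 2 gives 1.05 and compound 3 gives -1.08.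

From the compounds shown here alone, whether activity follows the free hydroxy group or the lower lipophilicity stays open, as the two change together in this pair. Also open, going by these compounds, is how an ethyl group or a fluorine would behave at this place on the aromatic ring.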